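This account rests on a few compounds, and the source may have more. Where it says the series, first, only, none or still open, it means among the compounds named here.

Compound 1 `CC(C)(C)C1=CC(=O)C(NCc2ccccc2)=CC1=O` gives 19000 nM in a functional assay on NCI-H460 cells (Homo sapiens) for cytotoxicity, read by MTT assay, with a stated time of 72 h; a higher number here means a weaker inhibitor, a lower number a stronger inhibitor
Compound 2 `CNC1=CC(=O)C(C(C)(C)C)=CC1=O` gives 63000 nM in this assay

Of these two, compound 2 stands highest at 63000 nM and so is the weaker inhibitor. The next compound, compound 3 `CCCCCCCCNC1=CC(=O)C(C(C)(C)C)=CC1=O`, keeps the shared core and differs from compound 2 at one place: heptyl in place of hydrogen on a saturated chain carbon bound to an amine nitrogen and nothing else changes. Within the data shown here, only one measured step bears on this, and it falls at the same place. Losing phenyl gave a 3.3-fold higher number from compound 1 to compound 2 (0.52 log units; beyond the scatter) and so, read in reverse, a larger group there went with a lower number. A lower number of similar, modest size is therefore expected in this assay although heptyl has no ring and a single step is thin evidence. The estimate amounts to an expected 4.2-fold lower number from compound 2 to compound 3 (0.62 log units; beyond the scatter) and no more. For compound 3 the estimated value is 15000 nM with an expected range from 4000 nM to 50000 nM as its limits.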

Compound 3, half-maximal inhibitory concentration: 70000 nM
Estimate against measurement, compound 3: 4.7-fold (0.67 log units) below, and the stated range ends below it.
By their numbers in this assay, from the lowest: compound 1; then compounds 2 and 3 (each within the scatter of the next).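

In this assay, heptyl in place of hydrogen on a saturated chain carbon bound to an amine nitrogen gives a 1.1-fold higher number from compound 2 to compound 3 (0.05 log units; within the scatter) and so shows that a larger group at this place does not by itself go with a lower number. Heptyl in place of phenyl at the same place gives a 3.7-fold higher number from compound 1 to compound 3 (0.57 log units; beyond the scatter) and leaves compound 1, the only one of the three carrying a ring in this group, set apart from compound 2 and compound 3. Nothing at hand explains this difference between phenyl and heptyl.

The compounds shown leave open whether any ring at this place would go with a lower number or only phenyl would, which a cyclohexyl group could help to settle. They also leave open how a shorter chain such as ethyl, or a chain ending in an amine, would compare.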